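A few compounds are considered here, and "the series" means these few. Any claim that something is new, unique, unknown or untested is made for them only; others in the source may bear on it.

Working notes on the series. Compound 1 `O=C(CN1CCCCC1)Nc1ccc(-c2nc3cc(C(F)(F)F)ccc3[nH]2)cc1` gives 6000 nM in an ADME assay on MT4 cells (Homo sapiens) for cytotoxicity, read by MTT assay, with a stated time of 96 h; on this read-out lower numbers stand for higher toxicity in this test and higher numbers for lower toxicity in this test; compound 2 `CC(=O)Nc1ccc(-c2nc3cc(C(F)(F)F)ccc3n2C2CCCCC2)cc1` gives 24000 nM; compound 3 `O=C(CCl)Nc1ccc(-c2nc3cc(C(F)(F)F)ccc3[nH]2)cc1` gives 5000 nM, the lowest of the three numbers, with compound 1 within the scatter of it and compound 2 beyond it. Compound 4 `CC(=O)Nc1ccc(-c2nc3cc(C(F)(F)F)ccc3[nH]2)cc1` is not yet measured. The change followed is hydrogen in place of chloro on a saturated chain carbon bound to a carbonyl carbon. Going by the values given here, no measured step makes this exact exchange. The nearest is a 1.2-fold lower number from compound 1 to compound 3 (0.08 log units; within the scatter), an exchange at the same carbon with no effect beyond the scatter. Compound 2 differs from compound 4 in two places, so its value bears on the step only loosely. A small step is expected, a 1.6-fold higher number from compound 3 to compound 4 (0.20 log units; within the scatter), if anything toward a higher number. Compound 4 is therefore estimated at 8000 nM, range 3000 nM to 25000 nM.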

Compound 4, half-maximal cytotoxic concentration: 19000 nM
Compound 4: the middle estimate sits 2.4-fold (0.38 log units) below what was measured; the range from low to high includes it.
By their numbers in this assay, from the lowest: compounds 3 and 1 (each within the scatter of the next); then compounds 4 and 2 (each within the scatter of the next).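

In this assay, the saturated chain carbon bound to a carbonyl carbon proves sensitive after all: hydrogen there gives a 3.8-fold higher number from compound 3 to compound 4 (0.58 log units; beyond the scatter) and a 3.2-fold higher number from compound 1 to compound 4 (0.50 log units; beyond the scatter), although chloro and piperidin-1-yl showed no difference beyond the scatter. On the aromatic nitrogen, hydrogen in place of cyclohexyl gives a 1.3-fold lower number from compound 2 to compound 4 (0.10 log units; within the scatter), which is within the scatter. Nothing available explains the higher numbers with hydrogen on the chain carbon. Going by these compounds, whether a primary amine, a carboxylic acid or a longer chain at that carbon would group with compound 4 or with compound 3 remains open.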